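Working notes on the amide-side change toward compound 3

This account rests on a few compounds, and the source may have more. Where it says the series, first, only, none or still open, it means among the compounds named here.

Measured so far:
compound 1 `CCN(CC)S(=O)(=O)c1ccc(S(=O)(=O)N2CCC[C@@H](C(=O)NC3CN(C(=O)C4CC4)C3)C2)cc1` — 2800 nM
compound 2 `CCN(CC)S(=O)(=O)c1ccc(S(=O)(=O)N2CCC[C@@H](C(=O)NC3CN(C(=O)NC(C)(C)C)C3)C2)cc1` — 3400 nM
not yet measured: compound 3 `CCN(CC)S(=O)(=O)c1ccc(S(=O)(=O)N2CCC[C@@H](C(=O)N[C@H]3CCN(C(=O)OC(C)(C)C)C3)C2)cc1`

In a functional assay on MIA PaCa-2 cells (Homo sapiens) for inhibition, read by MTT assay, with a stated time of 7 days (on this read-out higher numbers stand for weaker inhibition and lower numbers for stronger inhibition), compound 2 gives 3400 nM and sits within the scatter of compound 1, which gives 2800 nM; the step of a 1.2-fold higher number from compound 1 to compound 2 (0.08 log units; within the scatter) does not separate the two. Compound 3 carries 1-(tert-butoxycarbonyl)pyrrolidin-3-yl in place of 1-((tert-butyl)carbamoyl)azetidin-3-yl on an amide-type nitrogen. Within the data shown here, the only measured step, a 1.2-fold higher number from compound 1 to compound 2 (0.08 log units; within the scatter), concerns the substituent on the carbonyl carbon of that side chain and was within the scatter; no measured step covers a change of the ring itself. Among the measured compounds shown here, with no precedent for the ring change, compound 3 is expected to give a number close to that of compound 2, a step of a 1.0-fold higher number from compound 2 to compound 3 (0.01 log units; within the scatter), with a wide range. The estimate for compound 3 in this assay is 3500 nM, expected between 1200 nM and 11000 nM.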

Compound 3, half-maximal inhibitory concentration: 100 nM
The estimate for compound 3 lay 35-fold (1.54 log units) above the measured number; measured number outside the range, below it.
By their numbers in this assay, from the lowest: compound 3; then compounds 1 and 2 (each within the scatter of the next).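

Working notes, after compound 3: In this assay the substituent on the amide-type nitrogen is a sensitive place. The earlier change on the carbonyl carbon stayed within the scatter, but 1-(tert-butoxycarbonyl)pyrrolidin-3-yl gives a 34-fold lower number from compound 2 to compound 3 (1.53 log units; beyond the scatter) and a 28-fold lower number from compound 1 to compound 3 (1.45 log units; beyond the scatter) and so reaches far beyond it. No measurement here accounts for this gain.

The step changes the ring, the carbonyl substituent and the defined stereocentre together, so the share of each cannot be separated. From the compounds shown here alone, the opposite stereocentre and a free pyrrolidine amine or an acetyl group in place of tert-butoxycarbonyl remain open.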